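The source may hold more compounds than are shown below. What is called first, only, known or untested is meant among the compounds shown, and "the series" means these compounds.

Three compounds share one core. Compound 1 `CC(=O)n1nc(-c2ccccc2)nc1C` gives 439 mg/kg in a functional assay on the whole organism with Mus musculus as the target; on this read-out lower numbers stand for an effect already at smaller amounts and higher numbers for an effect only at larger amounts of compound. Compound 2 `CC(=O)n1nc(-c2ccc(C)cc2)nc1C` reaches only > 600 mg/kg in this assay, which is a limit of the assay (the limit of > 600 mg/kg in this assay, at which 1 of the 3 values shown sits). Compound 3 `CC(=O)n1nc(-c2ccc(Cl)cc2)nc1C` gives 342 mg/kg in this assay, the lowest of the two numbers present. The step between them is a 1.3-fold lower number from compound 1 to compound 3 (0.11 log units; within the scatter). The remaining steps, an at least 1.3-fold higher number from compound 1 to compound 2 (0.13 log units; that floor lies within the scatter) and an at least 1.7-fold lower number from compound 2 to compound 3 (0.24 log units; that floor lies within the scatter), sit on an aromatic carbon as well. Compound 4 `CCc1nc(-c2ccc(Cl)cc2)nn1C(C)=O` differs from compound 3 by methyl in place of hydrogen on a saturated chain carbon bound to an aromatic carbon. Within the data shown here, no measured step touches that carbon, and every measured step stays within the scatter, so no step beyond the scatter is expected: a 1.0-fold lower number from compound 3 to compound 4 (0.00 log units; within the scatter). Compound 4 is therefore estimated at 340 mg/kg, between 170 mg/kg and 680 mg/kg.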

Compound 4, dose for 50% inhibition: 543 mg/kg
The estimate for compound 4 lay 1.6-fold (0.20 log units) below the measured number, and the stated range covers the measured number.
By their numbers in this assay, from the lowest: compounds 3, 1 and 4 (each within the scatter of the next). At a limit, above all of these: compound 2.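

Among these compounds, the step of a 1.6-fold higher number from compound 3 to compound 4 (0.20 log units; within the scatter) is the first reading at the saturated chain carbon bound to an aromatic carbon, a place no earlier step touched. In this assay methyl to ethyl at this place, on the chloro compound, gives no difference that stands out from the scatter. Compound 4 still gives a number, not a limit: the limit of > 600 mg/kg in this assay, at which 1 of the 4 values shown sits.

Going by these compounds, whether a longer chain or an amine at this carbon would move the number beyond the scatter stays open. So does whether methyl to ethyl reads the same without the chloro group.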